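A few compounds are considered here, and "the series" means these few. Any claim that something is new, unique, unknown or untested is made for them only; others in the source may bear on it.

Measured compounds in a functional assay on HeLa cells (Homo sapiens) for cytotoxicity, read by cell counting, with a stated time of 48 h; on this read-out lower numbers stand for an effect already at smaller amounts and higher numbers for an effect only at larger amounts of compound:
compound 1, `C=CCCCCCCCCC(=O)O[C@H]1[C@H](O)[C@H](n2ccc(N)nc2=O)O[C@@H]1CO`, with 0.05 ug/mL
compound 2, `CC(=O)O[C@H]1[C@H](O)[C@H](n2ccc(N)nc2=O)O[C@@H]1CO`, with 0.14 ug/mL

Among the measured compounds shown here, compound 2 stands at the higher of the two numbers so far; its only neighbour is compound 1, and the one measured step is a 2.8-fold higher number from compound 1 to compound 2 (0.45 log units; beyond the scatter), a modest step beyond the scatter, in which the non-8-en-1-yl chain on the saturated chain carbon bound to the carbonyl carbon was replaced by hydrogen.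

Compound 3, `CCCC(=O)O[C@H]1[C@H](O)[C@H](n2ccc(N)nc2=O)O[C@@H]1CO`, is not yet measured in this assay. It differs from compound 2 in one place: ethyl in place of hydrogen on a saturated chain carbon bound to a carbonyl carbon. The step from compound 1 to compound 2 is the only one that bears on this change, since it concerns the same place; it went with a higher number when the long chain was removed. Compound 3 restores only the ethyl part of such a chain, so the step expected is in the reverse direction and smaller, estimated as a 1.6-fold lower number from compound 2 to compound 3 (0.19 log units; within the scatter). For compound 3 the estimated value in this assay is 0.09 ug/mL, with an expected range from 0.04 ug/mL to 0.2 ug/mL.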

Compound 3, concentration for half-maximal effect: 0.11 ug/mL
Compound 3: middle estimate off by 1.2-fold (0.09 log units), on the low side; low and high end bracket the measured number.
By their numbers in this assay, from the lowest: compound 1; then compounds 3 and 2 (each within the scatter of the next).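

In this assay, ethyl in place of hydrogen on a saturated chain carbon bound to a carbonyl carbon gives a 1.3-fold lower number from compound 2 to compound 3 (0.10 log units; within the scatter), so the change from acetyl to propylcarbonyl does not separate these two compounds. Hydrogen in place of hept-6-en-1-yl on a saturated chain carbon, three bonds along the chain from a carbonyl carbon, gives a 2.2-fold higher number from compound 1 to compound 3 (0.34 log units; beyond the scatter), so among these three compounds only the full non-8-en-1-yl chain of compound 1 stands apart beyond the scatter, and the first added ethyl accounts for no measurable part of that separation.

The chain length at which a step beyond the scatter first appears remains open, since nothing shown lies between the ethyl of compound 3 and the non-8-en-1-yl of compound 1. Also open, on these data alone, are whether a fully saturated chain of the same length as in compound 1 would match its number, and how an amine or a carboxylic acid at the end of the chain would read. No evidence in hand gives a reason for either step.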